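A fluoro substituent tested on a weakly active phenyl urea

The source may report more compounds than this note shows. Statements on the series, on what has been measured and on what is new or still open speak of the compounds shown alone.

Compound 3 `O=C(Nc1ccccc1)Nc1nc2ccc(F)cc2s1` is the unsubstituted phenyl member of this small set. In a functional assay on SK-HEP1 cells (Homo sapiens) for antiproliferative activity, read by sulforhodamine B assay (on this read-out lower numbers stand for stronger inhibition of growth and higher numbers for weaker inhibition of growth), compound 3 gives only a limit, > 10 ug/mL, and no number. Its nitro analogue compound 1 `O=C(Nc1cccc([N+](=O)[O-])c1)Nc1nc2ccc(F)cc2s1` gives 1.96 ug/mL in this assay, so an at least 5.1-fold higher number from compound 1 to compound 3 (0.70 log units; beyond the scatter). Compound 2 `COc1ccccc1NC(=O)Nc1nc2ccc(F)cc2s1` carries a methoxy group; in this assay compound 2 also reaches only a limit, > 10 ug/mL. Hence a step that the two limits leave unreadable from compound 2 to compound 3. Two of the three values sit at the limit of > 10 ug/mL in this assay, at which 2 of the 3 values shown sit, which leaves compound 3 without a read number and clearly weaker than compound 1.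

Compound 4 `O=C(Nc1nc2ccc(F)cc2s1)Nc1ccccc1F` differs from compound 3 by fluoro in place of hydrogen on an aromatic carbon. Of the measured steps, the nitro removal is the only readable one, and it concerned a different group; the methoxy step cannot be sized. Nothing measured speaks for a single fluoro group restoring growth inhibition, and the step that the limit leaves unreadable from compound 3 to compound 4 is therefore expected to stay within the scatter. Compound 4 is estimated at 12 ug/mL, between 4 ug/mL and 30 ug/mL.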

Compound 4, concentration for 50% growth inhibition: > 10 ug/mL
Compound 4 gave a limit, no number; the forecaster's own chance of this, stated with the estimate: 65%; the middle value lies beyond the limit too.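

Compound 4 gives only a limit, so no new step can be read from compound 2 or compound 3 to compound 4 in this assay: the limit of > 10 ug/mL in this assay, at which 3 of the 4 values shown sit. The compounds shown leave open how compound 2, compound 3 and compound 4 actually compare with one another.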